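Working notes: fused-ring substituent swap, compound 3 to compound 4

The source may report more compounds than this note shows. Statements on the series, on what has been measured and on what is new or still open speak of the compounds shown alone.

Measured so far in a functional assay on Bel-7402 cells (Homo sapiens) for cytotoxicity, read by MTT assay, with a stated time of 72 h; a lower number here means a stronger inhibitor, a higher number a weaker inhibitor:
compound 1 `O=C(Nc1ccc(-n2ncc3c(C(F)(F)F)cccc32)cc1)Nc1ccc(Cl)c(C(F)(F)F)c1` gives 16000 nM;
compound 2 `O=C(Nc1ccc(-n2ncc3ccccc32)cc1)Nc1ccc(Cl)c(C(F)(F)F)c1` gives 10600 nM;
compound 3 `O=C(Nc1ccc(-n2ncc3c(C(F)(F)F)cccc32)cc1)Nc1ccc(C(F)(F)F)cc1` gives 1000 nM.

Within the data shown here, compound 3 stands lowest of the three, and its distance to both compound 2 and compound 1 lies beyond the scatter, so it is the strongest inhibitor in this assay so far. Among the measured compounds shown here, the only large step recorded is a 16-fold lower number from compound 1 to compound 3 (1.20 log units; beyond the scatter), a change on the amide-type nitrogen side. Compound 4 `O=C(Nc1ccc(-n2ncc3c(Cl)cccc32)cc1)Nc1ccc(C(F)(F)F)cc1` differs from compound 3 elsewhere: chloro in place of trifluoromethyl on an aromatic carbon. The step that bears on this is a 1.5-fold lower number from compound 1 to compound 2 (0.18 log units; within the scatter), a change at the same aromatic carbon of the fused ring, which stayed within the scatter. Nothing measured here links a chloro group at this position to a shift in this assay. The expected step is therefore none beyond the scatter, that is no change at the digits printed from compound 3 to compound 4 (within the scatter). For compound 4 the estimate in this assay is 1000 nM, with a range from 400 nM to 2500 nM.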

Compound 4, half-maximal inhibitory concentration: 8000 nM
For compound 4 the middle estimate is 8.0-fold (0.90 log units) below the measured one; the whole stated range lies below it.
By their numbers in this assay, from the lowest: compound 3; then compounds 4, 2 and 1 (each within the scatter of the next).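

On this aromatic carbon of the fused ring, with 4-(trifluoromethyl)phenyl on the other side of the urea, this assay shows an 8.0-fold higher number from compound 3 to compound 4 (0.90 log units; beyond the scatter) on going to chloro in place of trifluoromethyl. The position is therefore not silent: the earlier step at the same carbon, a 1.5-fold lower number from compound 1 to compound 2 (0.18 log units; within the scatter) with hydrogen in place of trifluoromethyl, carried 4-chloro-3-(trifluoromethyl)phenyl and gave no sign of this sensitivity. No measurement at hand accounts for the shift.

The compounds shown leave open whether the shift belongs to chloro itself or to the 4-(trifluoromethyl)phenyl partner, with the two steps at this carbon differing in both the entering group and the partner. Going by these compounds, how a methyl group or an amine on this carbon would read also remains open.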